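This account rests on a few compounds, and the source may have more. Where it says the series, first, only, none or still open, it means among the compounds named here.

Compound 2 `NC(=O)c1nc(C#Cc2ccc(F)cc2)n(COCCO)n1` carries a 4-fluorophenyl group and a hydroxyethoxymethyl chain on the shared core. In an ADME assay on Huh-5-2 cells (Homo sapiens) for cytotoxicity (on this read-out higher numbers stand for lower toxicity in this test and lower numbers for higher toxicity in this test), compound 2 gives > 50 ug/mL, which is a limit of the assay and not a number. Compound 1 `COc1ccc(C#Cc2nc(C(N)=O)nn2COCCO)cc1` is the corresponding methoxy analogue. In this assay compound 1 gives > 50 ug/mL, likewise a limit. Going by the values given here, the step that the two limits leave unreadable from compound 1 to compound 2 therefore cannot be sized, and the only measured evidence is the limit of > 50 ug/mL in this assay, at which 2 of the 2 values shown sit. Compound 3 `NC(=O)c1nc(C#CCCCCl)n(COCCO)n1` differs from compound 2 by 3-chloropropyl in place of 4-fluorophenyl on a triple-bonded carbon. Among the compounds with values here, no measured step bears on a 3-chloropropyl replacing an aromatic ring, so the expectation rests solely on both measured compounds sitting at the limit in this assay. For compound 3 the expected step is a step that the limit leaves unreadable from compound 2 to compound 3, nothing beyond the scatter. Compound 3 is estimated at 60 ug/mL, within 30 ug/mL to 200 ug/mL, most probably reported again as a limit.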

Compound 3, half-maximal cytotoxic concentration: > 50 ug/mL
Compound 3 ended at the assay's limit; the forecaster's own chance of this, stated with the estimate: 75%; the middle value lies beyond the limit too.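

In this assay compound 3 gives > 50 ug/mL, a limit and not a number, so no step can be read from compound 2 to compound 3. The compounds shown leave open how far each lies beyond the read-out's reach, and whether either replacement changes cytotoxicity, with only this to go on: the limit of > 50 ug/mL in this assay, at which 3 of the 3 values shown sit.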